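The source may report more compounds than this note shows. Statements on the series, on what has been measured and on what is new or still open speak of the compounds shown alone.

The shared core, seen in compound 1 `Cc1cc(C)c(NC(=O)N(Cc2ccc(-c3ccccc3)o2)C2CCCCCC2)c(C)c1` and compound 2 `Cc1cc(C)c(NC(=O)N(Cc2ccc(-c3n[nH]c(C)n3)cc2)C2CCCCCC2)c(C)c1`, carries a different aromatic tail in each, and compound 3 `CSc1cc(C)nc(SC)c1NC(=O)N(Cc1ccccc1)Cc1cccc(-c2cnn(C)c2)c1` changes the core itself. In a functional assay on a cell-free system (plasma) with sterol O-acyltransferase, Soat (Rattus norvegicus) as the target (a higher number here means that more compound is needed for the effect, a lower number that less compound is needed), compound 1 is reported only as a limit, < 1 mg/kg. Compound 2 also gives only a limit in this assay, > 1 mg/kg. For compound 3 the result in this assay is likewise a limit, > 0.1 mg/kg. Among the compounds with values here, compound 2 therefore stands at the limit (the limit of > 1 mg/kg in this assay, at which 1 of the 3 values shown sits), compound 1 at the limit of < 1 mg/kg in this assay, at which 1 of the 3 values shown sits, and compound 3 at the limit (the limit of > 0.1 mg/kg in this assay, at which 1 of the 3 values shown sits); none of these is a number, so no measured step between any pair can be drawn, and no pattern across the three can be claimed.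

Compound 4 `Cc1cc(C)c(NC(=O)N(Cc2ccc(-n3cncn3)cc2)C2CCCCCC2)c(C)c1` differs from compound 2 in one place (1H-1,2,4-triazol-1-yl in place of 5-methyl-1H-1,2,4-triazol-3-yl on an aromatic carbon). Within the data shown here, no measured pair of this kind exists here, and the change itself is modest in size. The step that the limit leaves unreadable from compound 2 to compound 4 is therefore expected to stay within the usual scatter, with no clear direction. For compound 4 the dose for half-maximal effect in this assay is estimated at 2 mg/kg, with a range from 0.7 mg/kg to 6 mg/kg.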

Compound 4, dose for half-maximal effect: > 1 mg/kg
Compound 4: a limit, no number; the forecaster's own chance of this, stated with the estimate: 60%; the middle value does not contradict the limit.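

Within the data shown here, compound 2 and compound 4 are both reported in this assay only as limits, and no step between them can be read. The compounds shown leave open whether 1H-1,2,4-triazol-1-yl in place of 5-methyl-1H-1,2,4-triazol-3-yl changes the dose for half-maximal effect, and in which direction.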